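A few compounds are considered here, and "the series" means these few. Any claim that something is new, unique, unknown or untested is made for them only; others in the source may bear on it.

In a functional assay on NCI-H460 cells (Homo sapiens) for cytotoxicity (on this read-out higher numbers stand for weaker inhibition and lower numbers for stronger inhibition), compound 1 `CS(=O)(=O)c1ccc2nc(NC(=O)CCCCC(=O)NO)sc2c1` returns only a limit, > 30 ug/mL, so its place among the numbers shown is known only as that bound, (the limit of > 30 ug/mL in this assay, at which 1 of the 3 values shown sits). Its companions replace the methylsulfonyl group: compound 2 `Cc1ccc2nc(NC(=O)CCCCC(=O)NO)sc2c1` gives 11 ug/mL in this assay, and compound 3 `COc1ccc2nc(NC(=O)CCCCC(=O)NO)sc2c1` gives 21.4 ug/mL. The corresponding steps are an at least 2.7-fold lower number from compound 1 to compound 2 (0.43 log units; beyond the scatter) and an at least 1.4-fold lower number from compound 1 to compound 3 (0.14 log units; that floor lies within the scatter). Compound 4 `CCOc1ccc2nc(NC(=O)CCCCC(=O)NO)sc2c1` carries the change (ethoxy in place of methylsulfonyl on an aromatic carbon). Its closest measured relatives are compound 3 and compound 2, whose steps from compound 1 point downward, one at least modestly. A comparable downward step, an at least 1.7-fold lower number from compound 1 to compound 4 (0.24 log units; that floor lies within the scatter), is therefore expected. Compound 4 is estimated to give 17 ug/mL in this assay, between 8 ug/mL and 35 ug/mL.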

Compound 4, half-maximal inhibitory concentration: 7.96 ug/mL
Beside the measured number, compound 4's estimate is 2.1-fold (0.33 log units) above it; measured number outside the range, below it.
By their numbers in this assay, from the lowest: compounds 4, 2 and 3 (each within the scatter of the next, the first and the last beyond it). At a limit, above all of these: compound 1.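

In this assay, a methyl in place of hydrogen on the chain carbon bound to the oxygen is enough to matter at this position, with a 2.7-fold lower number from compound 3 to compound 4 (0.43 log units; beyond the scatter). Ethoxy and methyl cannot be told apart here, with a 1.4-fold lower number from compound 2 to compound 4 (0.14 log units; within the scatter). Replacing methylsulfonyl with ethoxy gives an at least 3.7-fold lower number from compound 1 to compound 4 (0.57 log units; beyond the scatter), a step beyond the scatter that methoxy did not establish.

On these data alone, the full size of that step stays open, since compound 1 gives only a limit: the limit of > 30 ug/mL in this assay, at which 1 of the 4 values shown sits. Whether a longer chain on the oxygen would continue this trend, or how an amine or a carboxylic acid would read here, also remains open.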